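The compounds below may be only part of what the source reports. "The series", "measured", "known", "first", "only" and "open" are said of these compounds alone.

Of the compounds shown here, three that share one core have been measured in a physicochemical assay for solubility, in phosphate buffer, at pH 7.4; on this read-out lower numbers stand for lower solubility and higher numbers for higher solubility. Compound 1 `CC(=O)N[C@@H]1CCC[C@H](C(=O)Nc2cc(-c3cnc(C)n3C(C)C)ccn2)C1` gives 660000 nM. Compound 2 `CC(=O)N[C@@H]1CCC[C@H](C(=O)Nc2cc(-c3cnn4c3CCCC4)c(F)cn2)C1` gives > 1000000 nM, which is a limit of the assay and not a number. Compound 3 `CC(=O)N[C@@H]1CCC[C@H](C(=O)Nc2cc(-c3cnc4ccccn34)c(Cl)cn2)C1` gives 120000 nM, the lowest number of the set, and its gap to compound 1, the nearest number, lies beyond the usual scatter.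

Compound 4 `CC(=O)N[C@@H]1CCC[C@H](C(=O)Nc2cc(-c3cnn4c3CN(C)CC4)c(Cl)cn2)C1` keeps the chloro group of compound 3 and changes one group, on an aromatic carbon opposite the ring nitrogen: a group of 10 heavy atoms (7 carbon, 3 nitrogen; one five-membered aromatic ring with 2 hetero atoms, one six-membered non-aromatic ring with 2 hetero atoms) in place of a group of 9 heavy atoms (7 carbon, 2 nitrogen; one five-membered aromatic ring with 2 hetero atoms, one six-membered aromatic ring with 1 hetero atom), on an aromatic carbon. Going by the values given here, no measured pair shows this change on its own, so any forecast is loose. Compound 2, whose group at that place also holds a six-membered non-aromatic ring, stands at > 1000000 nM, again a limit, although it differs elsewhere too. On this single comparison, an upward step in this assay beyond the scatter is expected. The estimated change is a 5.8-fold higher number from compound 3 to compound 4 (0.77 log units; beyond the scatter). For compound 4 the expected value is 700000 nM, with an estimated range from 300000 nM to 1000000 nM.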

Compound 4, solubility: 870000 nM
Estimate against measurement, compound 4: 1.2-fold (0.09 log units) below; the range from low to high includes it.
By their numbers in this assay, from the lowest: compound 3; then compounds 1 and 4 (each within the scatter of the next). At a limit, above all of these: compound 2.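

Going by these compounds alone, with the chloro group held fixed, compound 3 and compound 4 form the first pair that differs in one place, so this change on the aromatic carbon opposite the ring nitrogen can be read on its own. In this assay, exchanging the group with a six-membered aromatic ring for the one with a six-membered non-aromatic ring gives a 7.3-fold higher number from compound 3 to compound 4 (0.86 log units; beyond the scatter), showing that this position alone can move the read-out beyond the scatter. Compound 2 stands at a limit of the assay, so further rises in this series may not be readable as numbers: the limit of > 1000000 nM in this assay, at which 1 of the 4 values shown sits.

This single pair cannot separate the loss of the aromatic ring from the gain of a nitrogen in the entering group. From the compounds shown here alone, how a simple amine or a carboxylic acid would read at this position also remains open, as does whether the step holds without the chloro group.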